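Swapping Chloro for Iodo on a Weak Inhibitor

This account rests on a few compounds, and the source may have more. Where it says the series, first, only, none or still open, it means among the compounds named here.

Of the compounds shown here, three sharing one core have been measured. Compound 1 `Cc1cc2c(cc1C)C(Cl)=C(C(=O)N/N=C\c1ccc(F)cc1)CCC2` gives 3500 nM in a functional assay on IMR-32 cells (Homo sapiens) for inhibition, read by sulforhodamine B assay, with a stated time of 48 h; a lower number here means a stronger inhibitor of growth, a higher number a weaker inhibitor of growth. Compound 2 `Cc1ccc(C(=O)N/N=C/C2=C(Cl)c3cc(C)c(C)cc3CCC2)cc1` gives 100 nM. Compound 3 `Cc1cc2c(cc1C)C(Cl)=C(/C=N/NC(=O)c1cccc(Cl)c1)CCC2` gives > 100000 nM, which is a limit of the assay and not a number. Compound 3 thus sits at the limit of > 100000 nM in this assay, at which 1 of the 3 values shown sits, the top end of what the assay reports.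

Compound 4 `Cc1cc2c(cc1C)C(Cl)=C(/C=N/NC(=O)c1cccc(I)c1)CCC2` differs from compound 3 by iodo in place of chloro on an aromatic carbon. Among the measured compounds shown here, the only measured step, an at least 1000-fold higher number from compound 2 to compound 3 (3.00 log units; beyond the scatter), concerns the aromatic ring on the carbonyl carbon, not a swap of one halogen for another, so no measured step bears on this change. The step of a number no higher from compound 3 to compound 4 (the limit leaves the size open) is expected to be small. Compound 4 is estimated at 100000 nM, with a range from 20000 nM to 300000 nM, and is expected to be reported again as a limit.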

Compound 4, concentration for 50% growth inhibition: 1900 nM
The estimate for compound 4 lay 53-fold (1.72 log units) above the measured number, outside the stated range (below it).
By their numbers in this assay, from the lowest: compound 2; then compounds 4 and 1 (each within the scatter of the next). At a limit, above all of these: compound 3.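

Within this assay, one halogen on this ring decides much of the result: iodo in place of chloro gives an at least 52-fold lower number from compound 3 to compound 4 (1.72 log units; beyond the scatter). Compound 3 stands at a limit of the assay, not at a number: the limit of > 100000 nM in this assay, at which 1 of the 4 values shown sits. The 3-iodophenyl group still does not match the 4-methylphenyl group, with a 19-fold higher number from compound 2 to compound 4 (1.28 log units; beyond the scatter).

From the compounds shown here alone, whether bromo or an amine at the same place would behave like iodo or like chloro remains open. So does whether the same swap would have a similar effect on a different core.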